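A few compounds are considered here, and "the series" means these few. Any claim that something is new, unique, unknown or untested is made for them only; others in the source may bear on it.

Working notes on a small dienone series examined in a functional assay on LNCaP cells (Homo sapiens) for cytotoxicity, read by MTT assay, with a stated time of 72 h; on this read-out lower numbers stand for stronger inhibition and higher numbers for weaker inhibition.

Compound 1, `CC1=CCCC(C)(C)C1/C=C/C(=O)/C=C/c1ccccc1F`, gives 1600 nM. Compound 2, `CC1=CCCC(C)(C)C1/C=C/C(=O)/C=C/c1cc(C(F)(F)F)ccc1F`, gives 1700 nM. The two are linked by a single change, (trifluoromethyl in place of hydrogen on an aromatic carbon), and the resulting step of a 1.1-fold higher number from compound 1 to compound 2 (0.03 log units; within the scatter) lies within the scatter, so the two values are read as indistinguishable. Compound 3, `CC1=C(/C=C/C(=O)/C=C/c2ccc(F)cc2)C(C)(C)CCC1O`, gives 3900 nM in this assay; its number is the highest of the three, and its separation from compound 1 and from compound 2 is beyond the scatter in each case. The difference between the core of compound 3 and the core of compound 1 is not broken down here.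

Compound 4, `CC1=C(/C=C/C(=O)/C=C/c2ccc(F)c(C(F)(F)F)c2)C(C)(C)CCC1O`, has not yet been measured. It is related to compound 3 by trifluoromethyl in place of hydrogen on an aromatic carbon. For the measured compounds named here, this is the same kind of change as the one from compound 1 to compound 2, not the same: in compound 2 the entering group sits meta to a large group and para to a fluoro group, whereas in compound 4 it sits ortho to a fluoro group and meta to a large group. For compound 4 the expected step in this assay is a 1.0-fold higher number from compound 3 to compound 4 (0.01 log units; within the scatter). That expectation rests on compound 2, whose step a 1.1-fold higher number from compound 1 to compound 2 (0.03 log units; within the scatter) stayed within the scatter, and on compound 3 with its value 3900 nM as the starting point. Compound 4 is accordingly estimated at 4000 nM, with a plausible range from 2000 nM to 8000 nM.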

Compound 4, half-maximal inhibitory concentration: 2200 nM
Beside the measured number, compound 4's estimate is 1.8-fold (0.26 log units) above it; measured number inside the range.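

In this assay, trifluoromethyl in place of hydrogen on an aromatic carbon gives a 1.8-fold lower number from compound 3 to compound 4 (0.25 log units; within the scatter), so on this second core the step again stays within the scatter. Set beside the earlier step, it does not differ from it: the same change on two cores in this assay, a 1.1-fold higher number (0.03 log units; within the scatter) from compound 1 to compound 2 and a 1.8-fold lower number (0.25 log units; within the scatter) from compound 3 to compound 4, 1.9-fold (0.27 log units) apart, within the scatter of two such steps. Within these two pairs, then, the change carries from the core of compound 1 to the core of compound 3 without a step beyond the scatter, but this does not show that the same holds on other cores, and the pairs do not separate core from place, as the entering group in compound 4 sits ortho to a fluoro group and meta to a large group, a placing not shared with compound 2.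

The compounds shown leave open how the two cores would compare with trifluoromethyl at one identical place on the ring, and whether the step would stay as small with no fluoro group on that ring. They also leave open whether another group entering at the same aromatic carbon, such as an amine, a carboxylic acid or a longer chain like butyl, would give a step beyond the scatter on either core.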